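A few compounds are considered here, and "the series" means these few. Any claim that something is new, unique, unknown or untested is made for them only; others in the source may bear on it.

Of the compounds shown here, three sharing one core have been measured in an ADME assay (liver) for pharmacokinetics, with Liver microsome (Rattus norvegicus) as the target, using microsomes; a lower number here means that the compound disappears faster, a higher number that the compound lasts longer. Compound 1 `CCOc1cc(NC(=O)C2(NC(=O)c3ccc4c(C5CCCC5)c(-c5ncc(Cl)cn5)n(C)c4c3)CCC2)ccc1/C=C/C(=O)OCOP(=O)(O)O` gives 0.15 h. Compound 2 `CCCCCCOC(=O)/C=C/c1ccc(NC(=O)C2(NC(=O)c3ccc4c(C5CCCC5)c(-c5ncc(Cl)cn5)n(C)c4c3)CCC2)cc1OCC` gives 12.7 h, and compound 3 `CCOc1cc(NC(=O)C2(NC(=O)c3ccc4c(C5CCCC5)c(-c5ncc(Cl)cn5)n(C)c4c3)CCC2)ccc1/C=C/C(=O)OCC(=O)OCc1ccc(Cl)cc1` gives 11.4 h. Compound 3 therefore sits second highest of the three numbers: its number is within the scatter of that of compound 2, and it stands far above compound 1, as the step of a 76-fold higher number from compound 1 to compound 3 (1.88 log units; beyond the scatter) shows. The companion step an 85-fold higher number from compound 1 to compound 2 (1.93 log units; beyond the scatter) is of similar size, while the step of a 1.1-fold lower number from compound 2 to compound 3 (0.05 log units; within the scatter) is within the scatter.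

Compound 4 `CCOc1cc(NC(=O)C2(NC(=O)c3ccc4c(C5CCCC5)c(-c5ncc(Cl)cn5)n(C)c4c3)CCC2)ccc1/C=C/C(=O)OCC(=O)N1CCOCC1` differs from compound 3 by morpholin-4-yl in place of (4-chlorobenzyl)oxy on a carbonyl carbon. Going by the values given here, the only measured step at that position that does not involve the phosphorus-containing group, the step from compound 2 to compound 3, was within the scatter, so the data give no reason to expect a large movement in this assay, in either direction, though an exchange of an oxygen-linked group for a nitrogen-linked ring has not been tested here. The expected step of a 1.4-fold lower number from compound 3 to compound 4 (0.15 log units; within the scatter) is therefore modest. Compound 4 is estimated at 8 h, within a range of 2.5 h to 20 h.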

Compound 4, half-life: 0.733 h
Beside the measured number, compound 4's estimate is 11-fold (1.04 log units) above it, outside the stated range (below it).
By their numbers in this assay, from the lowest: compound 1; then compound 4; then compounds 3 and 2 (each within the scatter of the next).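

In this assay the carbonyl carbon proves sensitive to what it carries: a 16-fold lower number from compound 3 to compound 4 (1.19 log units; beyond the scatter) follows when morpholin-4-yl replaces (4-chlorobenzyl)oxy, so the near-equal numbers of compound 2 and compound 3 do not extend to every group here. The change from pentyl to (morpholin-4-yl)carbonyl gives a drop of similar size, seen in a 17-fold lower number from compound 2 to compound 4 (1.24 log units; beyond the scatter) as a large step. Compound 4 still does not fall to the level of the phosphorus-containing compound, as a 4.9-fold higher number from compound 1 to compound 4 (0.69 log units; beyond the scatter) shows with a modest step, so it sits between the two extremes.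

Nothing available explains why the number falls. Open, on these data alone, is whether the fall follows the nitrogen link or the morpholine ring itself, and a piperidin-1-yl or benzylamino group on the same carbonyl carbon would separate the two.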